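The source may report more compounds than this note shows. Statements on the series, on what has been measured and on what is new or still open speak of the compounds shown alone.

Measured compounds:
- compound 1 `COc1ccc(Nc2nc3ccccc3nc2S(=O)(=O)c2ccccc2)cc1`, which in a functional assay on KB cells (Homo sapiens) for cytotoxicity, read by MTT assay, with a stated time of 72 h (a lower number here means a stronger inhibitor, a higher number a weaker inhibitor), gives "not determined" (no result reported)
- compound 2 `Nc1ccc(Nc2nc3ccccc3nc2S(=O)(=O)c2ccccc2)cc1`, which in this assay gives 3400 nM
- compound 3 `O=S(=O)(c1ccccc1)c1nc2ccccc2nc1Nc1ccc(Cl)cc1`, which in this assay gives 41200 nM

All three compounds share one core and differ only in the group that sits on the outer phenyl ring. Compound 1 carries a methoxy group there, but no number for it is known in this assay, so it cannot be placed among the others on the numbers shown. The unmeasured compound 4 `O=S(=O)(c1ccccc1)c1nc2ccccc2nc1Nc1ccc(C(F)(F)F)cc1` is reached from compound 1 by one change: trifluoromethyl in place of methoxy on an aromatic carbon.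

For the measured compounds named here, only one measured step bears on this change, and only at a distance. It is a 12-fold higher number from compound 2 to compound 3 (1.08 log units; beyond the scatter). Both chloro and trifluoromethyl are small groups without a hydrogen-bond acceptor, in contrast to amino and methoxy, which each carry one. That single step is a weak guide, since compound 1 itself has no number to anchor the comparison. A step toward a higher number in this assay is expected, in line with the direction seen for compound 3, with wide uncertainty. Compound 4 is therefore expected to give about 30000 nM, within a range from 8000 nM to 120000 nM.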

Compound 4, half-maximal inhibitory concentration: > 50000 nM
Compound 4: no number, only a limit; the forecaster's own chance of this, stated with the estimate: 20%; middle value at least 1.6-fold (0.22 log units) from the limit.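

For compound 4, the reading in this assay is > 50000 nM, a limit of the assay and not a number. Trifluoromethyl in place of amino gives an at least 14-fold higher number from compound 2 to compound 4 (1.16 log units; beyond the scatter), so compound 4 joins compound 3 in lying well beyond the scatter from compound 2, and among the three compounds with a reading, the amino group of compound 2 alone gives the lower number. Trifluoromethyl in place of chloro gives an at least 1.2-fold higher number from compound 3 to compound 4 (0.08 log units; that floor lies within the scatter), which does not order these two groups, and no step from compound 1 can be read, for it has no number.

From the compounds shown here alone, the place of methoxy therefore stays open, and with it the direct effect of exchanging methoxy for trifluoromethyl. Also open, going by these compounds, is whether the lower number belongs to amino alone or would also appear with a hydroxy group, a methylamino group or an acetamido group on the same carbon of the outer ring.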